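Moving the chlorine on the benzylsulfanyl group

The source may report more compounds than this note shows. Statements on the series, on what has been measured and on what is new or still open speak of the compounds shown alone.

Compound 1 `COc1ccc(C2N=C(SCc3ccccc3Cl)NC(C)=C2C(=O)Nc2ccc(F)cc2)cc1OC` gives 35.9% in a functional assay on the whole organism (artery, strain albino) with Rattus norvegicus as the target, with a stated time of 300 min, at a dose of 10 mg/kg by the oral route; a lower number here means less inhibition, a higher number more inhibition at the dose given (going by the name of the read-out). Compound 2 `COc1ccc(C2N=C(SCc3cccc(Cl)c3)NC(C)=C2C(=O)Nc2ccc(F)cc2)cc1OC` differs from it only in one respect, (3-chlorophenyl in place of 2-chlorophenyl on a saturated chain carbon bound to a sulfur); in this assay compound 2 gives 16.4%, so that a number 19.5 percentage points lower from compound 1 to compound 2 (beyond the scatter). Compound 3 `COc1ccc(C2N=C(SCc3ccccc3Cl)NC(C)=C2C(=O)Nc2ccc(Br)cc2)cc1` carries the same 2-chlorophenyl as compound 1 but on a different core; the difference between the two cores is not broken down here. In this assay compound 3 gives 17.9%, close to compound 2 and short of compound 1.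

Compound 4 `COc1ccc(C2N=C(SCc3cccc(Cl)c3)NC(C)=C2C(=O)Nc2ccc(Br)cc2)cc1` stands to compound 3 as compound 2 stands to compound 1: 3-chlorophenyl in place of 2-chlorophenyl on a saturated chain carbon bound to a sulfur, the same change at the same place. Among the measured compounds shown here, only one earlier step of this kind is known, the one from compound 1 to compound 2, and it was made on another core. Because compound 3 already sits at 17.9%, a drop as large as a number 19.5 percentage points lower from compound 1 to compound 2 (beyond the scatter) cannot be repeated in full, so the step from compound 3 to compound 4 is expected to be about a number 12.9 percentage points lower from compound 3 to compound 4 (beyond the scatter). For compound 4 the expected inhibition is estimated at 5%, between -8% and 18%.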

Compound 4, a percentage reported as inhibition, in the whole organism at one dose (the size of the read-out at that dose, not a potency): 39%
Compound 4: the middle estimate sits 34 percentage points below what was measured, and the stated range ends below it.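

On the second core, 3-chlorophenyl in place of 2-chlorophenyl on a saturated chain carbon bound to a sulfur gives a number 21.1 percentage points higher from compound 3 to compound 4 (beyond the scatter) in this assay. The change therefore does not carry over from one core to the other with a fixed size or even a fixed direction, as the two steps run opposite ways: the same change on two cores in this assay, a number 19.5 percentage points lower (beyond the scatter) from compound 1 to compound 2 and a number 21.1 percentage points higher (beyond the scatter) from compound 3 to compound 4, 40.6 percentage points apart, beyond the scatter of two such steps. This shows that, for these two pairs, the outcome of the swap depends on the core it is made on, but it does not show which part of the cores is responsible, and two pairs at a single oral dose give no general rule for the series.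

What the compounds shown leave open is how a plain benzyl, a methoxybenzyl or a longer chain between the sulfur and the ring would behave on either core. Also open, going by these compounds, is whether an amine or a carboxylic acid on that ring would follow either of the two steps.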